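A few compounds are considered here, and "the series" means these few. Any claim that something is new, unique, unknown or untested is made for them only; others in the source may bear on it.

In a functional assay on HepG2 cells (Homo sapiens) for antiproliferative activity, read by MTT assay, with a stated time of 72 h; on this read-out higher numbers stand for weaker inhibition and lower numbers for stronger inhibition:
- compound 1 `COc1ncc(-c2ccc3c(c2)N(c2ccc(C)cc2)C(=O)CO3)cc1NS(=O)(=O)c1ccc(F)cc1`: 28300 nM
- compound 2 `COc1ncc(-c2ccc3c(c2)N(c2ccccc2)C(=O)CO3)cc1NS(=O)(=O)c1ccc(F)cc1`: 14000 nM

Compound 2 holds the lower of the two numbers. Compound 3 `COc1ncc(-c2ccc3c(c2)N(C(C)C)C(=O)CO3)cc1NS(=O)(=O)c1ccc(F)cc1` differs from it by isopropyl in place of phenyl on an amide-type nitrogen in a ring, with isopropyl in place of phenyl on an amide-type nitrogen in a ring. Among the compounds with values here, only one measured step bears on this change, and only indirectly: a 2.0-fold lower number from compound 1 to compound 2 (0.31 log units; beyond the scatter), a modest step with hydrogen in place of methyl on an aromatic carbon. That step altered the aromatic group that leaves here but did not replace it. Within the data shown here, no compound measured so far has a non-aromatic group at this place, so the direction is poorly supported. In this assay, a small move towards a lower number is expected, possibly none beyond the scatter. The expected step is a 1.2-fold lower number from compound 2 to compound 3 (0.07 log units; within the scatter). For compound 3 the estimated value is 12000 nM, with an expected range of 4000 nM to 35000 nM.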

Compound 3, half-maximal inhibitory concentration: 37200 nM
The estimate for compound 3 lay 3.1-fold (0.49 log units) below the measured number, and the stated range ends below it.
By their numbers in this assay, from the lowest: compound 2; then compounds 1 and 3 (each within the scatter of the next).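

Notes on the substituent on the amide-type nitrogen: in this assay, isopropyl, the only non-aromatic group shown here, does not hold the level of compound 2 (a 2.7-fold higher number from compound 2 to compound 3 (0.42 log units; beyond the scatter)). Against the 4-methylphenyl of compound 1, isopropyl shows no separation (a 1.3-fold higher number from compound 1 to compound 3 (0.12 log units; within the scatter)), so of the three groups only the unsubstituted phenyl of compound 2 stands apart, and an aromatic ring at this place does not by itself give the lower number. Nothing on hand accounts for either step.

As far as these compounds go, one non-aromatic group cannot show whether isopropyl stands for that class, so cyclopropyl, a longer chain such as n-butyl or a chain ending in an amine remains open. Also open, from the compounds shown here alone, is whether a phenyl carrying fluorine or methoxy would stay with compound 2 or with compound 1.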